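Fluoro on the pendant phenyl: compound 2 to compound 3

A few compounds are considered here, and "the series" means these few. Any claim that something is new, unique, unknown or untested is made for them only; others in the source may bear on it.

The series shares a urea-bearing core. Compound 1 `CN(Cc1ccccc1Cl)C(=O)Nc1c(-c2ccc(F)cc2)c2ccccc2c(=O)n1C` carries a chloro on the benzyl and a fluoro on the pendant phenyl, while compound 2 `CN(Cc1ccccc1)C(=O)Nc1c(-c2ccccc2)c2ccccc2c(=O)n1C` carries neither. In an assay on IM-9 cells for binding affinity to Substance-P receptor (Homo sapiens) (a higher number here means a weaker inhibitor, a lower number a stronger inhibitor), compound 1 gives 480 nM. In this assay, within the data shown here, compound 2 gives 110 nM, the lower of the two numbers; compound 1 differs from it in two places at once, so the two values show only that compound 1 sits beyond the scatter above compound 2, without saying which of the two changes carries the gap.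

Compound 3 `CN(Cc1ccccc1)C(=O)Nc1c(-c2ccc(F)cc2)c2ccccc2c(=O)n1C` takes one of those two changes on its own: fluoro in place of hydrogen on an aromatic carbon, on the ring that hangs from the shared core. Among the measured compounds shown here, no measured pair differs by this change alone, so the size of the step in this assay is open. The expectation is a small step or none beyond the scatter, in the weakening direction if any, given that compound 1 gives 480 nM with this fluoro present alongside the chloro. For compound 3 in this assay the estimated value is 160 nM, with a range from 80 nM to 320 nM. This estimate implies a step of a 1.5-fold higher number from compound 2 to compound 3 (0.16 log units; within the scatter), expected to stay within the scatter.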

Compound 3, half-maximal inhibitory concentration: 1500 nM
The estimate for compound 3 lay 9.4-fold (0.97 log units) below the measured number; the measured number lies above the stated range.
By their numbers in this assay, from the lowest: compound 2; then compound 1; then compound 3.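

In this assay the change from phenyl to 4-fluorophenyl, taken alone on the ring hanging from the shared core, gives a 14-fold higher number from compound 2 to compound 3 (1.13 log units; beyond the scatter) and so marks this position as sensitive to even a single fluoro in place of hydrogen. With that fluoro kept, hydrogen in place of chloro on the benzyl gives a 3.1-fold higher number from compound 1 to compound 3 (0.49 log units; beyond the scatter). The gap between compound 1 and compound 2 thus resolves into two steps of opposite direction, a large one that raises the number with the fluoro and a modest one that lowers it with the chloro. No measurement here bears on why the fluoro step is so large.

As far as these compounds go, whether the chloro goes with a lower number on the unsubstituted phenyl as well remains open, since its step is read only with the fluoro present. Also open, from the compounds shown here alone, is whether this position penalises substitution in general or fluoro in particular, a question that a methyl, a methoxy or an amine in the same place would address.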